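This account rests on a few compounds, and the source may have more. Where it says the series, first, only, none or still open, it means among the compounds named here.

Measured in an ADME assay on HEK293 cells (Homo sapiens) for cytotoxicity, read by resazurin assay, with a stated time of 72 h; a higher number here means that more compound is tolerated, a lower number that less compound is tolerated:
Compound 1 `O=C(O)c1ccc(CCOc2c(F)ccc3nc(C(=O)NCc4ccccc4)[nH]c(=O)c23)cc1`: > 20000 nM, a limit
Compound 2 `CCc1ccccc1CNC(=O)c1nc2ccc(F)c(OCCc3ccc(C(=O)O)cc3)c2c(=O)[nH]1`: > 20000 nM, a limit

Compound 2 therefore has no number, and it stands at the limit of > 20000 nM in this assay, at which 2 of the 2 values shown sit. Compound 3 `CCc1ccc(CNC(=O)c2nc3ccc(F)c(OCCc4ccc(C(=O)O)cc4)c3c(=O)[nH]2)cc1` carries the same atoms joined differently, with 4-ethylphenyl in place of 2-ethylphenyl on a saturated chain carbon bound to an amide-type nitrogen. Among the compounds with values here, the one measured step that bears on this is a step that the two limits leave unreadable from compound 1 to compound 2. With no readable step to go on, nothing beyond the scatter is expected in this assay, and the expected step is a number no higher from compound 2 to compound 3 (the limit leaves the size open). Compound 3 is estimated at 20000 nM, with an expected range from 10000 nM to 40000 nM.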

Compound 3, half-maximal cytotoxic concentration: > 20000 nM
Compound 3 was reported as a limit; the forecaster's own chance of this, stated with the estimate: 85%; the middle value lies on the limit itself.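

No step can be read among compound 1, compound 2 and compound 3, since all three sit at the same limit: the limit of > 20000 nM in this assay, at which 3 of the 3 values shown sit. The compounds shown leave open whether adding the ethyl group, or changing 2-ethylphenyl to 4-ethylphenyl, alters tolerance at all.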